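The compounds below may be only part of what the source reports. "The series", "measured", "known", "first", "only" and "open" are said of these compounds alone.

Measured so far in a functional assay on A549 cells (Homo sapiens) for cytotoxicity, read by MTT assay, with a stated time of 4 days; a lower number here means a stronger inhibitor, a higher number a weaker inhibitor:
- compound 1 `C=C1C[C@]23C[C@@]1(O)CC[C@H]2c1ccc(O)c(C)c1[C@@H]3Cn1cc(-c2ccc(OC)cc2)nn1`, > 20000 nM
- compound 2 `Cc1c(O)ccc2c1[C@H](Cn1cc(-c3ccc(F)cc3)nn1)[C@@]13CC(=O)[C@@](C)(CC[C@@H]21)C3`, > 20000 nM
- compound 3 `Cc1ccc(S(=O)(=O)Oc2ccc3c(c2C)[C@H](Cn2cc(-c4ccc(Br)cc4)nn2)[C@@]24CC(=O)[C@@](C)(CC[C@@H]32)C4)cc1`, > 20000 nM

Each of these three values is a limit of the assay and not a number. In this assay compound 1 gives > 20000 nM as a limit. In this assay compound 2 gives > 20000 nM as a limit. In this assay compound 3 gives > 20000 nM as a limit. Compound 3 therefore stands where the whole measured set stands, at the limit of > 20000 nM in this assay, at which 3 of the 3 values shown sit; no compound in the set has returned a number, so no step between measured compounds can be sized, and nothing separates compound 3 from compound 1 or compound 2 on the numbers shown.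

The next compound, compound 4 `Cc1ccc(-c2cn(C[C@H]3c4c(ccc(OS(=O)(=O)c5ccc(C)cc5)c4C)[C@@H]4CC[C@@]5(C)C[C@]43CC5=O)nn2)cc1`, is to be measured in this assay. It differs from compound 3 by methyl in place of bromo on an aromatic carbon, the rest of the structure unchanged.

Among the measured compounds shown here, no step in this assay is available to set a direction, and the expectation rests only on the fact that compound 3 sits at the limit of > 20000 nM in this assay, at which 3 of the 3 values shown sit. Compound 4 is expected to stay at that same limit, so the expected step from compound 3 to compound 4 is a step that the limit leaves unreadable from compound 3 to compound 4, none beyond the scatter. For compound 4 the estimate in this assay is 30000 nM, with a range from 12000 nM to 100000 nM, most likely again reported only as a limit.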

Compound 4, half-maximal inhibitory concentration: > 20000 nM
Compound 4 gave a limit, no number; the forecaster's own chance of this, stated with the estimate: 85%; the middle value is on the limit's open side.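

In this assay compound 4 gives > 20000 nM, a limit and not a number. Compound 3 also stands at a limit, so no step can be read from the exchange of bromo for methyl between compound 3 and compound 4: the limit of > 20000 nM in this assay, at which 4 of the 4 values shown sit.

The compounds shown leave open which structural change, if any, gives a measurable value in this assay.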